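Carbamoyl for methylsulfanyl at the limit of the assay

The compounds below may be only part of what the source reports. "The series", "measured", "known", "first", "only" and "open" are said of these compounds alone.

In an ADME assay on Raji cells (Homo sapiens) for cytotoxicity, with a stated time of 72 h (a lower number here means that less compound is needed, a higher number that more compound is needed for the effect), compound 3 (`CSc1ccccc1NC(=O)Nc1cc(C)nc2ccccc12`) shows > 25000 nM as a limit and not a number. Compound 1 (`Cc1cc(NC(=O)Nc2ccccc2OC(F)(F)F)c2ccccc2n1`) shows > 25000 nM as a limit too. Compound 2 (`Cc1cc(NC(=O)Nc2ccccc2N)c2ccccc2n1`) also shows > 25000 nM as a limit. Compound 4 (`Cc1cc(NC(=O)Nc2ccccc2C(N)=O)c2ccccc2n1`) carries carbamoyl in place of methylsulfanyl on an aromatic carbon of the shared core. The measured steps bearing on this place are a step that the two limits leave unreadable from compound 1 to compound 3 and a step that the two limits leave unreadable from compound 2 to compound 3 and neither has a size that can be read. The evidence is the limit of > 25000 nM in this assay, at which 3 of the 3 values shown sit, alone. No size can be carried over, so the expected a number no higher from compound 3 to compound 4 (the limit leaves the size open) in this assay is none beyond the scatter. Compound 4 is estimated at 25000 nM within an expected range of 12000 nM to 50000 nM and will most likely appear as a limit again.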

Compound 4, half-maximal effective concentration: > 25000 nM
Compound 4 ended at the assay's limit; the forecaster's own chance of this, stated with the estimate: 85%; the middle value lies on the limit itself.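

In this assay compound 4 gives > 25000 nM, a limit and not a number. Within the data shown here, compound 1, compound 2 and compound 3 also stand at limits, so no step to compound 4 can be read. The compounds shown leave open whether any group at this place gives a value that can be read as a number in this assay.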